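The source may report more compounds than this note shows. Statements on the series, on what has been measured and on what is new or still open speak of the compounds shown alone.

Compound 2, `Nc1scc(CN2CCN(c3ccccc3C(F)(F)F)CC2)c1C(=O)c1ccc(Cl)cc1`, is an aminothiophene with a piperazine carrying an aryl group; in a functional assay on CHO cells with adenosine receptor A1 (Homo sapiens) as the target, read by cAMP accumulation and immunoassay, with a stated time of 6 min, tested at 0.1 uM (on this read-out higher numbers stand for a weaker effect at the one concentration tested and lower numbers for a stronger effect), compound 2 gives -7.5%. Going by the values given here, its only measured neighbour, compound 1, `Nc1scc(CN2CCN(c3ccc(Cl)cc3Cl)CC2)c1C(=O)c1ccc(Cl)cc1`, gives -11% in this assay, and the two lie within the usual scatter of each other, the step being a number 3.5 percentage points higher from compound 1 to compound 2 (within the scatter). Compound 3, `Nc1scc(CN2CCN(c3ccc(Cl)c(C(F)(F)F)c3)CC2)c1C(=O)c1ccc(Cl)cc1`, differs from compound 2 by 4-chloro-3-(trifluoromethyl)phenyl in place of 2-(trifluoromethyl)phenyl on an amine nitrogen in a ring. Among the compounds with values here, the one measured step that bears on this, a number 3.5 percentage points higher from compound 1 to compound 2 (within the scatter), also exchanged the aryl group on the ring nitrogen and stayed within the scatter, so no step beyond the scatter is expected here: a number 0.5 percentage points lower from compound 2 to compound 3 (within the scatter). Compound 3 is therefore estimated at -8%, with a range from -25% to 10%.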

Compound 3, a percentage reported as activity, at one concentration (the size of the read-out at that concentration, not a potency): -12%
Estimate against measurement, compound 3: 4 percentage points above; the range from low to high includes it.
By their numbers in this assay, from the lowest: compounds 3, 1 and 2 (each within the scatter of the next).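

On the amine nitrogen in the ring, 4-chloro-3-(trifluoromethyl)phenyl gives two more small steps in this assay: a number 4.5 percentage points lower from compound 2 to compound 3 (within the scatter), and a number 1 percentage points lower from compound 1 to compound 3 (within the scatter). Three different chlorine or trifluoromethyl patterns on this phenyl ring, including one that carries both groups, therefore read alike at this position. Nothing available explains this sameness.

The compounds shown leave open whether a phenyl ring bearing an amine or a carboxylic acid would also stay within the scatter. A single concentration also shows only the size of the effect at that concentration, and leaves unknown whether compounds 1, 2 and 3 would differ in stronger or weaker effect at any other.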